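Compound 1 to compound 3: dropping the methoxymethyl

The source may hold more compounds than are shown below. What is called first, only, known or untested is meant among the compounds shown, and "the series" means these compounds.

Compound 1 (`COCCN1CC[C@H](C)Nc2cc(ccc2C(N)=O)-n2c(c(C)c3c2CC(C)(C)CC3=O)CC1=O`) is the reference point for this step. In a physicochemical assay for solubility (on this read-out lower numbers stand for lower solubility and higher numbers for higher solubility), compound 1 gives > 100 ug/mL as a limit and not a number. In this assay compound 2 (`Cc1c2c(n3c1CCCN(C(=O)[C@@H](C)N)[C@H](C)CNc1cc-3ccc1C(N)=O)CC(C)(C)CC2=O`) gives > 100 ug/mL as a limit too. Together the two results come to the limit of > 100 ug/mL in this assay, at which 2 of the 2 values shown sit, and no step between measured compounds is available.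

Compound 3 (`Cc1c2c(n3c1CC(=O)N(C)CC[C@H](C)Nc1cc-3ccc1C(N)=O)CC(C)(C)CC2=O`) differs from compound 1 by hydrogen in place of methoxymethyl on a saturated chain carbon bound to an amide-type nitrogen in a ring which, cut one bond further out, reads 2-methoxyethyl to methyl.

Among the compounds with values here, the expectation has only one anchor on this step: compound 1 at > 100 ug/mL as a limit. A small downward move or none beyond the scatter is expected, and the estimated size is an at least 1.1-fold lower number from compound 1 to compound 3 (0.04 log units; that floor lies within the scatter) in this assay with wide uncertainty. In this assay the estimate for compound 3 is 90 ug/mL with an expected range from 30 ug/mL to 200 ug/mL and a real chance of again getting only a limit.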

Compound 3, solubility: > 100 ug/mL
Compound 3: only a limit was reported; the forecaster's own chance of this, stated with the estimate: 50%; middle value at least 1.1-fold (0.04 log units) away from the limit.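

In this assay compound 3 gives > 100 ug/mL, a limit and not a number. Compound 1 gives > 100 ug/mL, also a limit, so no step can be read for this pair. The compounds shown leave open whether hydrogen in place of methoxymethyl changes the read-out at all, as every value shown is the same limit: the limit of > 100 ug/mL in this assay, at which 3 of the 3 values shown sit.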